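Cyano to trifluoromethoxy on a second core

The source may report more compounds than this note shows. Statements on the series, on what has been measured and on what is new or still open speak of the compounds shown alone.

Compound 1 `CN1CCN(c2ccc(C3=NN(S(=O)(=O)c4ccc(C#N)cc4)C(c4ccc(N(C)C)cc4)C3)cc2)CC1` gives 99.8% in a functional assay on HCC1806 cells (Homo sapiens) for inhibition, read by sulforhodamine B assay, tested at 10 uM; a lower number here means less inhibition, a higher number more inhibition at the concentration tested (going by the name of the read-out). Compound 2 `CN1CCN(c2ccc(C3=NN(S(=O)(=O)c4ccc(OC(F)(F)F)cc4)C(c4ccc(N(C)C)cc4)C3)cc2)CC1` gives 70.8%, a step of a number 29 percentage points lower from compound 1 to compound 2 (beyond the scatter) for the change (trifluoromethoxy in place of cyano on an aromatic carbon). Compound 3 `CN(C)c1ccc(C2CC(c3ccc(-n4cncn4)cc3)=NN2S(=O)(=O)c2ccc(C#N)cc2)cc1` gives 33.1% and stands lowest of the three; its core differs from that of compound 1 by 1H-1,2,4-triazol-1-yl in place of 4-methylpiperazin-1-yl on an aromatic carbon, a step of a number 66.7 percentage points lower from compound 1 to compound 3 (beyond the scatter).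

Compound 4 `CN(C)c1ccc(C2CC(c3ccc(-n4cncn4)cc3)=NN2S(=O)(=O)c2ccc(OC(F)(F)F)cc2)cc1` is not yet measured. It differs from compound 3 by trifluoromethoxy in place of cyano on an aromatic carbon, the same change as from compound 1 to compound 2, at a place described in the same words, so the change is the same. Compound 3 has less room below it than compound 1 had, and the read-out cannot fall much further than to no inhibition at the concentration tested.

The step from compound 3 to compound 4 in this assay is expected to be a number 23.1 percentage points lower from compound 3 to compound 4 (beyond the scatter), smaller than the earlier one because a number 29 percentage points lower from compound 1 to compound 2 (beyond the scatter) already used most of the range that compound 3 retains with 33.1%. Compound 4 is estimated at 10%, between 0% and 30%.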

Compound 4, a percentage reported as inhibition, at one concentration (the size of the read-out at that concentration, not a potency): 25.2%
For compound 4 the middle estimate is 15.2 percentage points below the measured one; the range from low to high includes it.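

In this assay, trifluoromethoxy in place of cyano gives a number 7.9 percentage points lower from compound 3 to compound 4 (within the scatter), so on the triazole-bearing core the change does not carry the size it had on the core of compound 1: the same change on two cores in this assay, a number 29 percentage points lower (beyond the scatter) from compound 1 to compound 2 and a number 7.9 percentage points lower (within the scatter) from compound 3 to compound 4, 21.1 percentage points apart, beyond the scatter of two such steps

Seen from the other side, 1H-1,2,4-triazol-1-yl in place of 4-methylpiperazin-1-yl gives a number 45.6 percentage points lower from compound 2 to compound 4 (beyond the scatter), the same direction as on the cyano compounds but a different size: the same change on two cores in this assay, a number 66.7 percentage points lower (beyond the scatter) from compound 1 to compound 3 and a number 45.6 percentage points lower (beyond the scatter) from compound 2 to compound 4, 21.1 percentage points apart, beyond the scatter of two such steps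

Both gaps rest on the same four compounds, so they are a single non-additive result seen twice; it shows that the two changes cannot simply be summed here, but not why, and readings at one concentration do not give potencies.

Still open, going by these compounds, is whether the high readings stay with 4-methylpiperazin-1-yl alone or extend to another amine such as morpholin-4-yl. Also open, on these data alone, is how a chlorine or a methylsulfonyl group in place of cyano would behave on each of the two cores.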